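Working notes: expected tolerance of compound 4

This account rests on a few compounds, and the source may have more. Where it says the series, first, only, none or still open, it means among the compounds named here.

Measured so far:
compound 1 `CC(C)(C)OC(=O)N(Cc1ccco1)C(=O)c1ccc(CN2Cc3ccccc3S2(=O)=O)cc1`: > 100000 nM
compound 2 `CC(C)(C)OC(=O)N(Cc1ccco1)C(=O)c1ccc(CN2Cc3ccccc3C2=O)cc1`: 95200 nM
compound 3 `O=C(NCc1ccco1)c1ccc(CN2Cc3ccccc3C2=O)cc1`: > 100000 nM

Within the data shown here, in an ADME assay on RAW264.7 cells (Mus musculus) for cytotoxicity, read by WST assay (a higher number here means that more compound is tolerated, a lower number that less compound is tolerated), compound 2 gives 95200 nM, the only plain number in the set. For compound 1 the value > 100000 nM is a limit of the assay. For compound 3 the value > 100000 nM is likewise a limit. Compound 2 thus stands near (the limit of > 100000 nM in this assay, at which 2 of the 3 values shown sit). Compound 4 `CC(C)(C)OC(=O)N(Cc1ccco1)C(=O)c1ccc(CN2C(=O)c3ccccc3C2=O)cc1` differs from compound 2 by a group of 11 heavy atoms (8 carbon, 1 nitrogen, 2 oxygen; one five-membered non-aromatic ring with 1 hetero atom, one six-membered aromatic ring of carbon only) in place of a group of 10 heavy atoms (8 carbon, 1 nitrogen, 1 oxygen; one five-membered non-aromatic ring with 1 hetero atom, one six-membered aromatic ring of carbon only), on a saturated chain carbon bound to an aromatic carbon. The two measured steps touching compound 2, an at least 1.0-fold lower number from compound 1 to compound 2 (0.02 log units; that floor lies within the scatter) and an at least 1.0-fold higher number from compound 2 to compound 3 (0.02 log units; that floor lies within the scatter), concern different changes and both fall within the scatter, so they give no direction for this new change. Compound 4 is therefore expected to show no step beyond the scatter, a 1.1-fold higher number from compound 2 to compound 4 (0.02 log units; within the scatter). Compound 4 is estimated at 100000 nM, with a range from 50000 nM to 200000 nM.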

Compound 4, concentration lethal to 50% of the cells: > 100000 nM
Compound 4: a limit, no number; the forecaster's own chance of this, stated with the estimate: 60%; the middle value sits exactly at the limit.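

With the group carrying 2 double bonds outside aromatic rings in place of the one carrying 1, on a saturated chain carbon bound to an aromatic carbon, this assay shows an at least 1.0-fold higher number from compound 2 to compound 4 (0.02 log units; that floor lies within the scatter). Compound 4 thus adds a third ring group at this place without a readable loss of tolerance, though its value is a limit and not a number; the step from compound 1 to compound 4 cannot be read. The values of the series crowd at one ceiling: the limit of > 100000 nM in this assay, at which 3 of the 4 values shown sit.

Open, on these data alone, is how an amine or a carboxylic acid would fare at this place, in place of the ring group. Also open, as far as these compounds go, is whether any group here brings the tolerated concentration clearly under that limit.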